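The source may hold more compounds than are shown below. What is called first, only, known or untested is meant among the compounds shown, and "the series" means these compounds.

Working notes on the series.

Compound 1 `CCCCNc1nc(N)nc2c1CN(Cc1ccccc1)CC2` sits at the low end of the numbers seen so far: in an assay on HEK293 cells for agonist activity at Toll-like receptor 8 (Homo sapiens), read by a luciferase reporter, with a stated time of 6 h (on this read-out higher numbers stand for an effect only at larger amounts of compound and lower numbers for an effect already at smaller amounts), compound 1 gives 0.06 uM. The nearest of the others is compound 3 `CCCCNc1nc(N)nc2c1CN(Cc1c[nH]c3ccccc13)CC2`, which in this assay gives 0.22 uM, a gap beyond the scatter. Furthest is compound 2 `CCCCNc1nc(N)nc2c1CCN(C(=O)c1ccccc1)C2`, the only carbonyl-bearing member measured to date, which in this assay gives 0.8 uM, also well beyond the scatter. No pair among these three differs in one place only, so the numbers are read as they stand, not as steps.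

Compound 4 `CCCCNc1nc(N)nc2c1CN(C(=O)c1cc(C)on1)CC2` is not yet measured. It differs from compound 1 as follows: (5-methyl-1,2-oxazol-3-yl)carbonyl in place of benzyl on an amine nitrogen in a ring. Going by the values given here, with no measured step of this kind to draw on, the expectation rests on the standing of compound 2 at 0.8 uM relative to compound 1 at 0.06 uM: the move is expected to run toward higher numbers, with a step of an 8.3-fold higher number from compound 1 to compound 4 (0.92 log units; beyond the scatter) expected to exceed the scatter. For compound 4 in this assay the estimate is 0.5 uM, within a range of 0.1 uM to 3 uM.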

Compound 4, minimum effective concentration: 0.4 uM
Estimate against measurement, compound 4: 1.3-fold (0.10 log units) above; measured number inside the range.
By their numbers in this assay, from the lowest: compound 1; then compounds 3, 4 and 2 (each within the scatter of the next, the first and the last beyond it).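

Going by these compounds alone, at the amine nitrogen in the ring, this change gives the first one-place step in this assay: the exchange of benzyl for (5-methyl-1,2-oxazol-3-yl)carbonyl yields a 6.7-fold higher number from compound 1 to compound 4 (0.82 log units; beyond the scatter). On the core of compound 1, this position therefore does not tolerate every group alike, and the read-out moves when a carbonyl and a five-membered aromatic ring with 2 hetero atoms replace the benzyl group. Nothing available explains the direction or size of this step.

On these data alone, the carbonyl and the ring change together in this single step, so their separate contributions remain open. A (5-methyl-1,2-oxazol-3-yl)methyl group or a plain acetyl group on the same nitrogen would help to separate them.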